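Swapping 1-carboxyethyl for 1-carboxycyclopropyl in a clearance test

The source may hold more compounds than are shown below. What is called first, only, known or untested is meant among the compounds shown, and "the series" means these compounds.

Compound 1 `O=C(O)Cn1nc(Cc2nc3cc(F)c(OCC4CC4)cc3[nH]2)c2ccccc2c1=O` gives < 53.4 mL/min/kg (a limit)
Compound 2 `C[C@@H](C(=O)O)c1nn(Cc2cn3cc(OCC4CC4)c(Cl)cc3n2)c2ccccc2c1=O` gives < 55 mL/min/kg (a limit)

In an ADME assay on microsomes from liver (Mus musculus) for metabolic stability (a higher number here means faster removal of the compound, a lower number slower removal), compound 2 reads < 55 mL/min/kg as a limit of the assay, not a number. Compound 1 reads < 53.4 mL/min/kg as a limit too. Neither compound therefore has an exact clearance figure, and the two cannot be ranked.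

Compound 3 `O=C(O)C1(c2nn(Cc3cn4cc(OCC5CC5)c(Cl)cc4n3)c3ccccc3c2=O)CC1` differs from compound 2 in one place (1-carboxycyclopropyl in place of 1-carboxyethyl on an aromatic carbon) with 1-carboxycyclopropyl in place of 1-carboxyethyl on an aromatic carbon. Within the data shown here, no measured pair shows what this swap does. Among the measured compounds shown here, the only guide is compound 2 with its limit of < 55 mL/min/kg so no step beyond the usual scatter is expected in this assay in either direction. The expected step (a step that the limit leaves unreadable from compound 2 to compound 3) lies within that scatter. For compound 3 the estimate is 50 mL/min/kg with a range of 25 mL/min/kg to 85 mL/min/kg and the assay may again report only a limit.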

Compound 3, clearance: < 53.4 mL/min/kg
Compound 3 ended at the assay's limit (the forecaster's own chance of this, stated with the estimate: 75%); the middle value is on the limit's open side.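

Compound 2 and compound 3 both end at a limit in this assay, and the step between them cannot be read. The compounds shown leave open the exact clearance of each compound and whether 1-carboxycyclopropyl in place of 1-carboxyethyl shifts it in either direction.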